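Notes on the aryl-methyl variation in this coumarin series

The compounds below may be only part of what the source reports. "The series", "measured", "known", "first", "only" and "open" are said of these compounds alone.

Measured so far:
compound 1 `Cc1cc(F)ccc1Cc1c(C)c2ccc(OCC(O)CN3CCC(C(N)=O)CC3)cc2oc1=O` — > 100000 nM in an ADME assay on A549 cells (Homo sapiens) for cytotoxicity, read by CellTiter-Glo; a lower number here means that less compound is tolerated, a higher number that more compound is tolerated (a limit of this assay, no number)
compound 2 `COc1ccc(Cc2c(C)c3ccc(OCC(O)CN4CCC(C(N)=O)CC4)cc3oc2=O)c(Br)c1` — 44400 nM in this assay

Among the compounds with values here, compound 2 carries the only number seen in this assay; the other entry is a limit, (the limit of > 100000 nM in this assay, at which 1 of the 2 values shown sits). Within the data shown here, the single measured step runs an at least 2.2-fold lower number from compound 1 to compound 2 (0.35 log units; beyond the scatter), and it is the only comparison available.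

Compound 3 `Cc1c(Cc2ccc(OC(F)(F)F)cc2)c(=O)oc2cc(OCC(O)CN3CCC(C(N)=O)CC3)ccc12` is the next member. Its difference from compound 2: 4-(trifluoromethoxy)phenyl in place of 2-bromo-4-methoxyphenyl on a saturated chain carbon bound to an aromatic carbon. The measured step from compound 1 to compound 2 concerns the same position of the shared core, but it exchanges a different pair of groups, and it starts from a limit, so its size is known only as a lower bound. It gives no direction for a trifluoromethoxyphenyl group in this assay. The expectation for compound 3 is therefore a step within the scatter, a 1.1-fold higher number from compound 2 to compound 3 (0.05 log units; within the scatter), with a broad range that reaches the limit of this assay. Compound 3 is estimated at 50000 nM, between 15000 nM and 150000 nM.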

Compound 3, half-maximal cytotoxic concentration: 68200 nM
Beside the measured number, compound 3's estimate is 1.4-fold (0.13 log units) below it; the range from low to high includes it.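

The exchange of 2-bromo-4-methoxyphenyl for 4-(trifluoromethoxy)phenyl on a saturated chain carbon bound to an aromatic carbon gives a 1.5-fold higher number from compound 2 to compound 3 (0.19 log units; within the scatter), so these two substituted phenyl groups are not separated in this assay. The other new step, an at least 1.4-fold lower number from compound 1 to compound 3 (0.16 log units; that floor lies within the scatter), has only a floor and does not by itself set the 4-fluoro-2-methylphenyl group apart. The sole reading at this position beyond the scatter therefore remains an at least 2.2-fold lower number from compound 1 to compound 2 (0.35 log units; beyond the scatter), and it starts from a limit: the limit of > 100000 nM in this assay, at which 1 of the 3 values shown sits.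

The compounds shown all carry a substituted phenyl group at this place, so the reading of an unsubstituted phenyl group remains open. Also open, on these data alone, is how an amine or a carboxylic acid on this phenyl group would read in this assay.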